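The source may hold more compounds than are shown below. What is called first, only, known or untested is meant among the compounds shown, and "the series" means these compounds.

Within the data shown here, compound 2 `N#CC1=C(/N=C/c2ccccc2)N(c2ccccc2)C(=O)N2CCCCC(N3CCCC3)C12` gives 84% in a functional assay on the whole organism (strain albino) for inhibition, with Rattus norvegicus as the target, read by paw edema, with stated times of 1 h and 3 h, at a dose of 20 mmol/kg by the intraperitoneal route (a lower number here means a weaker effect, a higher number a stronger effect of the compound at the dose given), the second highest of the three numbers measured so far. Compound 3 `N#Cc1c2n(c(=O)n(-c3ccccc3)c1=N)CCCCC2N1CCCC1` gives 93.4% in this assay, which is within the scatter of compound 2, while compound 1 `N#CC1=C(NCC(=O)N2CCCC2)N(c2ccccc2)C(=O)N2CCCCC(N3CCCC3)C12` gives 56% in this assay, and the step of a number 28 percentage points higher from compound 1 to compound 2 (beyond the scatter) lies beyond the scatter. Compound 4 `N#CC1=C(NC(=O)c2ccccc2O)N(c2ccccc2)C(=O)N2CCCCC(N3CCCC3)C12` differs from compound 2 by a group of 10 heavy atoms (7 carbon, 1 nitrogen, 2 oxygen; one six-membered aromatic ring of carbon only) in place of a group of 8 heavy atoms (7 carbon, 1 nitrogen; one six-membered aromatic ring of carbon only), on a double-bonded ring carbon. Among the measured compounds shown here, only the step from compound 1 to compound 2 concerns a change at this same place, and it was modest, so a new group there may shift the number by a comparable amount in either direction or not at all. Compound 4 is therefore expected to give 70% in this assay, between 50% and 90%, which corresponds to an expected step of a number 14 percentage points lower from compound 2 to compound 4 (beyond the scatter).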

Compound 4, a percentage reported as inhibition, in the whole organism at one dose (the size of the read-out at that dose, not a potency): 65.4%
For compound 4 the middle estimate is 4.6 percentage points above the measured one; low and high end bracket the measured number.
By their numbers in this assay, from the lowest: compounds 1 and 4 (each within the scatter of the next); then compounds 2 and 3 (each within the scatter of the next).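

At this double-bonded ring carbon, ((2-hydroxyphenyl)carbonyl)amino in place of the group in compound 2 gives a number 18.6 percentage points lower from compound 2 to compound 4 (beyond the scatter) in this assay and shows that a group keeping the same aromatic ring can still lower the number. On the amine nitrogen, (2-hydroxyphenyl)carbonyl in place of ((pyrrolidin-1-yl)carbonyl)methyl gives a number 9.4 percentage points higher from compound 1 to compound 4 (within the scatter) and so shows no clear difference between these two groups. Nothing available explains either step. Still open, going by these compounds, is how a plain benzoyl group, a carboxylic acid or a longer alkyl chain on that amine nitrogen would compare with these groups.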